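A few compounds are considered here, and "the series" means these few. Any claim that something is new, unique, unknown or untested is made for them only; others in the source may bear on it.

Measured compounds:
Compound 1 `Cc1ccn2c(CCCCO)c(Cn3c(=O)n(C4CC4)c4ccncc43)nc2c1`; in an ADME assay on HEp-2 cells (Homo sapiens) for cytotoxicity, read by CCK-8 assay, with a stated time of 6 days (a lower number here means that less compound is tolerated, a higher number that more compound is tolerated), compound 1 reaches only the limit of the assay, > 100000 nM.
Compound 2 `O=c1n(Cc2nc3cc(Cl)ccn3c2CCCCO)c2cnccc2n1C1CC1`; in this assay compound 2 likewise reaches only the limit of the assay, > 100000 nM.

Compound 2 therefore stands at the limit rather than at a number, and the other value shown sits there too: the limit of > 100000 nM in this assay, at which 2 of the 2 values shown sit. Among the compounds with values here, the one measured step, a step that the two limits leave unreadable from compound 1 to compound 2, cannot be sized because both of its ends sit at the limit of > 100000 nM in this assay, at which 2 of the 2 values shown sit.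

Compound 3 `O=c1n(Cc2cn3ccc(Cl)cc3n2)c2cnccc2n1C1CC1` differs from compound 2 by hydrogen in place of 4-hydroxybutyl on an aromatic carbon. Within the data shown here, no measured step bears on this change; the only step in hand concerns a different group and is itself unreadable. So no size or direction of step can be derived for this assay. With both measured compounds at the limit, compound 3 is expected to sit near it as well, with an estimated value of 120000 nM and a range from 40000 nM to 400000 nM. The step that the limit leaves unreadable from compound 2 to compound 3 is expected to be none beyond the scatter.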

Compound 3, half-maximal cytotoxic concentration: 22300 nM
For compound 3 the middle estimate is 5.4-fold (0.73 log units) above the measured one; measured number below the stated range.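

In this assay, hydrogen in place of 4-hydroxybutyl on the aromatic carbon of the five-membered ring gives an at least 4.4-fold lower number from compound 2 to compound 3 (0.65 log units; beyond the scatter), the first change shown whose direction can be read. This place on the shared core therefore moves the read-out, and in this pair the compound without the chain is tolerated less: compound 3 gives a measured 22300 nM rather than a limit. The true size of the step remains unknown, as its upper end is only a limit, reached by compound 2: the limit of > 100000 nM in this assay, at which 2 of the 3 values shown sit.

Within the data shown here, the one pair does not separate the role of the chain's length from that of its hydroxyl, and a plain butyl chain, a shorter chain or an amine in place of the hydroxyl would be needed to tell these apart. From the compounds shown here alone, the step between the chloro and methyl compounds cannot be read, so it also remains open whether methyl in place of chloro would change the number once hydrogen occupies this place, as in compound 3.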